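This account rests on a few compounds, and the source may have more. Where it says the series, first, only, none or still open, it means among the compounds named here.

Compound 3 `CC(C)C(Cc1nnn[nH]1)c1ccc(-c2ccc3cccc(F)c3c2)[nH]c1=O` carries the highest number of the three measured compounds in a functional assay on CHO cells for antagonist activity at prostaglandin E2 receptor EP3 subtype (Homo sapiens), read by cAMP accumulation (a lower number here means a stronger inhibitor, a higher number a weaker inhibitor), giving 134 nM; compound 1 `CC(C)NC(=O)CC(c1ccc(-c2ccc3cccc(F)c3c2)[nH]c1=O)C(C)C` gives 15 nM and compound 2 `CC(C)C(c1ccc(-c2ccc3cccc(F)c3c2)[nH]c1=O)N1CCCCC1=O` gives 40 nM in the same assay. Compound 4 `CC(C)C(c1ncco1)c1ccc(-c2ccc3cccc(F)c3c2)[nH]c1=O` differs from compound 3 by 1,3-oxazol-2-yl in place of (1H-tetrazol-5-yl)methyl on a saturated chain carbon bound to an aromatic carbon and a saturated chain carbon. Two measured steps change this same position: a 2.7-fold higher number from compound 1 to compound 2 (0.43 log units; beyond the scatter) and a 3.4-fold higher number from compound 2 to compound 3 (0.53 log units; beyond the scatter), both modest and both beyond the scatter, so swapping the group here has so far moved the number by modest amounts in either sense. The oxazolyl group resembles none of the three groups already tried, so the direction is uncertain; a modest fall from compound 3 is expected, a 2.2-fold lower number from compound 3 to compound 4 (0.35 log units; beyond the scatter). Compound 4 is therefore estimated at 60 nM, with a range of 15 nM to 250 nM.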

Compound 4, half-maximal inhibitory concentration: 64 nM
The estimate for compound 4 lay 1.1-fold (0.03 log units) below the measured number; the range from low to high includes it.
By their numbers in this assay, from the lowest: compound 1; then compounds 2 and 4 (each within the scatter of the next); then compound 3.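

The directly attached 1,3-oxazol-2-yl improves on the (1H-tetrazol-5-yl)methyl it replaces (a 2.1-fold lower number from compound 3 to compound 4 (0.32 log units; beyond the scatter)), so a five-membered aromatic ring on this carbon need not carry the weakest number. It cannot be told apart from 2-oxopiperidin-1-yl (a 1.6-fold higher number from compound 2 to compound 4 (0.20 log units; within the scatter)), yet it still falls short of the (isopropylcarbamoyl)methyl group (a 4.3-fold higher number from compound 1 to compound 4 (0.63 log units; beyond the scatter)). Nothing measured here gives a reason for these steps. Going by these compounds, whether the difference from compound 3 comes from the ring or from the lost methylene link stays open. So does whether a (1,3-oxazol-2-yl)methyl group or a carboxylic acid on this carbon would match compound 1.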